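Swapping a hexyl chain for phenyl on an alkynyl nucleoside

This account rests on a few compounds, and the source may have more. Where it says the series, first, only, none or still open, it means among the compounds named here.

Measured compounds:
- compound 1, `CCCCC#Cc1c[nH]c(=O)[nH]c1=O`, 113000 nM
- compound 2, `CCCCCCC#Cc1cn([C@@H]2O[C@H](CO)[C@@H](O)[C@H]2O)c(=O)[nH]c1=O`, 15700 nM
- compound 3, `O=c1[nH]cc(C#CC(O)c2ccccc2)c(=O)[nH]1`, 38400 nM

All three compounds share a core carrying a triple bond, and all were tested in an ADME assay on MRC5 cells (Homo sapiens) for cytotoxicity, read by MTT assay; on this read-out higher numbers stand for lower toxicity in this test and lower numbers for higher toxicity in this test. Compound 2 gives 15700 nM, the lowest number of the three; the steps to compound 3 and to compound 1 both lie beyond the scatter, so compound 2 is the most toxic of the measured set here.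

Compound 4, `O=c1[nH]c(=O)n([C@@H]2O[C@H](CO)[C@@H](O)[C@H]2O)cc1C#Cc1ccccc1`, has not been measured. It differs from compound 2 in one place: phenyl in place of hexyl on a triple-bonded carbon. Among the measured compounds shown here, no measured pair shows this exact change, so the step cannot be read directly from the data. Compound 3, which also carries a phenyl beyond the triple bond, though with a different link and without the sugar, sits at a higher number than compound 2, which hints that the phenyl variant may be somewhat less toxic. The step from compound 2 to compound 4 is therefore expected to be moderate, toward a higher number, as a 1.9-fold higher number from compound 2 to compound 4 (0.28 log units; within the scatter). For compound 4 the estimate in this assay is 30000 nM, with a range from 8000 nM to 120000 nM.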

Compound 4, half-maximal cytotoxic concentration: 1200 nM
Beside the measured number, compound 4's estimate is 25-fold (1.40 log units) above it, outside the stated range (below it).
By their numbers in this assay, from the lowest: compound 4; then compound 2; then compound 3; then compound 1.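

In this assay, phenyl in place of hexyl on a triple-bonded carbon gives a 13-fold lower number from compound 2 to compound 4 (1.12 log units; beyond the scatter), so the swap makes the compound clearly more toxic in this test. Among the compounds shown here, this is the first pair that differs in one place only, and it shows that this position is sensitive to what sits on it, even though both groups have the same number of heavy atoms, all carbon, and neither adds a hydrogen-bond donor or acceptor. Nothing measured here explains why the two groups behave so differently.

A cyclohexyl group in the same place would help separate the effect of having a ring from that of having an aromatic ring. From the compounds shown here alone, whether the same swap has a similar effect without the sugar also remains open.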